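This account rests on a few compounds, and the source may have more. Where it says the series, first, only, none or still open, it means among the compounds named here.

For the measured compounds named here, in an assay on CHO cells for antagonist activity at transient receptor potential cation channel subfamily V member 1 (Homo sapiens), read by FLIPR (a higher number here means a weaker inhibitor, a lower number a stronger inhibitor), compound 2 `CC(C(=O)NCc1ccc(C(F)(F)F)nc1-c1ccc(F)c(Cl)c1)c1ccc(NS(C)(=O)=O)c(F)c1` gives 0.2 nM, the lowest number of the two measured so far, while compound 1 `CC(C(=O)NCc1ccc(C(F)(F)F)nc1-c1ccccc1)c1ccc(NS(C)(=O)=O)c(F)c1` gives 6.4 nM. Compound 3 `COc1ccc(-c2nc(C(F)(F)F)ccc2CNC(=O)C(C)c2ccc(NS(C)(=O)=O)c(F)c2)cc1F` differs from compound 2 by 3-fluoro-4-methoxyphenyl in place of 3-chloro-4-fluorophenyl on an aromatic carbon. Going by the values given here, the only measured step that bears on this position is a 32-fold lower number from compound 1 to compound 2 (1.51 log units; beyond the scatter), which shows that the group there can move the result a great deal. Compound 3 keeps a substituted ring at that position but loses the chlorine, so a modest rise in number is expected, a 4.0-fold higher number from compound 2 to compound 3 (0.60 log units; beyond the scatter). Compound 3 is therefore estimated at 0.8 nM in this assay, within 0.2 nM to 3 nM.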

Compound 3, inhibition constant: 4.2 nM
Compound 3: the middle estimate sits 5.3-fold (0.72 log units) below what was measured; measured number above the stated range.
By their numbers in this assay, from the lowest: compound 2; then compounds 3 and 1 (each within the scatter of the next).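

In this assay, a substituted ring at this position does not carry the gain by itself: a 21-fold higher number from compound 2 to compound 3 (1.32 log units; beyond the scatter), so 3-fluoro-4-methoxyphenyl gives back most of what 3-chloro-4-fluorophenyl gained. Against plain phenyl, the change is a 1.5-fold lower number from compound 1 to compound 3 (0.18 log units; within the scatter), which leaves the two together. The result here therefore depends on which substituents the ring carries, and nothing available explains the difference. Still open, going by these compounds, is whether the step follows the loss of chlorine or the arrival of methoxy, as both change between compound 2 and compound 3. A 3-chloro-4-methoxyphenyl group would separate the two.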